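This account rests on a few compounds, and the source may have more. Where it says the series, first, only, none or still open, it means among the compounds named here.

Measured compounds:
Compound 1 `O=C(Nn1c(-c2cccc([N+](=O)[O-])c2)nc2c(-c3ccc(Cl)cc3)n[nH]c2c1=O)c1cccnc1`: 19.7%
Compound 2 `O=C(Nn1c(-c2cccc([N+](=O)[O-])c2)nc2c(-c3ccc(F)cc3)n[nH]c2c1=O)c1cccnc1`: 28.8%
Compound 3 `O=C(Nn1c(-c2cccc([N+](=O)[O-])c2)nc2c(-c3ccc(Cl)cc3)n[nH]c2c1=O)c1ccccc1`: 88.6%

All three values come from a functional assay on A549 cells (Homo sapiens) for cytotoxicity, read by sulforhodamine B assay, with a stated time of 2 days, tested at 100 uM; on this read-out lower numbers stand for less inhibition and higher numbers for more inhibition at the one concentration tested (going by the name of the read-out). Compound 2 differs from compound 1 by fluoro in place of chloro on an aromatic carbon, and this change gave a number 9.1 percentage points higher from compound 1 to compound 2 (within the scatter). Compound 3 differs from compound 1 by phenyl in place of pyridin-3-yl on a carbonyl carbon, which gave a number 68.9 percentage points higher from compound 1 to compound 3 (beyond the scatter). Compound 4 `O=C(Nn1c(-c2cccc([N+](=O)[O-])c2)nc2c(-c3ccc(F)cc3)n[nH]c2c1=O)c1ccccc1` has not yet been measured. It differs from compound 3 by fluoro in place of chloro on an aromatic carbon, which is the same change as between compound 1 and compound 2, made at the same place. From compound 3 to compound 4 the expected step is a number 3.6 percentage points lower from compound 3 to compound 4 (within the scatter), a small one. This expectation rests on compound 1 and compound 2, where the step of a number 9.1 percentage points higher from compound 1 to compound 2 (within the scatter) stayed within the scatter. In this assay compound 4 is estimated to give 85%, with a likely range from 60% to 98%.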

Compound 4, a percentage reported as inhibition, at one concentration (the size of the read-out at that concentration, not a potency): 80.7%
The estimate for compound 4 lay 4.3 percentage points above the measured number, and the stated range covers the measured number.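

In this assay, fluoro in place of chloro on the core of compound 3 gave a number 7.9 percentage points lower from compound 3 to compound 4 (within the scatter), so each step for this swap is small on its own, yet the two do not match: the same change on two cores in this assay, a number 9.1 percentage points higher (within the scatter) from compound 1 to compound 2 and a number 7.9 percentage points lower (within the scatter) from compound 3 to compound 4, 17 percentage points apart, beyond the scatter of two such steps Phenyl in place of pyridin-3-yl gave a number 51.9 percentage points higher from compound 2 to compound 4 (beyond the scatter), a large rise on both the chloro and the fluoro cores, though of unequal size: the same change on two cores in this assay, a number 68.9 percentage points higher (beyond the scatter) from compound 1 to compound 3 and a number 51.9 percentage points higher (beyond the scatter) from compound 2 to compound 4, 17 percentage points apart, beyond the scatter of two such steps So the direction of the phenyl change carried over between these two cores while its exact size did not, and two pairs cannot show how either change behaves on any other core.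

Still open, as far as these compounds go, is how a methoxy group in place of the halogen, or an amine in place of the nitro group, would read. A single tested concentration also leaves the potency of these compounds open.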